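From Bromo to Iodo: an Expected Cytotoxicity Value

The compounds below may be only part of what the source reports. "The series", "measured", "known", "first", "only" and "open" are said of these compounds alone.

Compound 3 `O=c1cc(-c2ccccc2)oc2cc(OCCCCNc3nc4ccc(Br)cc4s3)cc(O)c12` in an ADME assay on MDCK cells (Canis lupus familiaris) for cytotoxicity, read by sulforhodamine B assay, with a stated time of 48 h (a lower number here means a stronger inhibitor, a higher number a weaker inhibitor), gives 289 ug/mL. As read, this is the lowest of the three numbers, yet its two neighbours sit within the scatter of it: compound 1 `Cc1ccc2nc(NCCCCOc3cc(O)c4c(=O)cc(-c5ccccc5)oc4c3)sc2c1` gives 294 ug/mL in this assay, and compound 2 `O=c1cc(-c2ccccc2)oc2cc(OCCCCNc3nc4ccc(Cl)cc4s3)cc(O)c12` gives 338 ug/mL. The steps between them are small: a 1.1-fold higher number from compound 1 to compound 2 (0.06 log units; within the scatter), a 1.0-fold lower number from compound 1 to compound 3 (0.01 log units; within the scatter) and a 1.2-fold lower number from compound 2 to compound 3 (0.07 log units; within the scatter). Each of these swaps one substituent for another on the same aromatic carbon, and none of them moved the number beyond the scatter.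

Compound 4 `O=c1cc(-c2ccccc2)oc2cc(OCCCCNc3nc4ccc(I)cc4s3)cc(O)c12` repeats this kind of swap: iodo in place of bromo on an aromatic carbon. All three measured steps bear on it. Because a 1.1-fold higher number from compound 1 to compound 2 (0.06 log units; within the scatter), a 1.0-fold lower number from compound 1 to compound 3 (0.01 log units; within the scatter) and a 1.2-fold lower number from compound 2 to compound 3 (0.07 log units; within the scatter) each stayed within the scatter, no change beyond the scatter is expected in this assay, in either direction. The expected step is a 1.0-fold higher number from compound 3 to compound 4 (0.00 log units; within the scatter). Compound 4 is therefore estimated at 290 ug/mL, with a range from 190 ug/mL to 440 ug/mL.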

Compound 4, half-maximal inhibitory concentration: 298 ug/mL
Compound 4: the middle estimate sits 1.0-fold (0.01 log units) below what was measured; the range from low to high includes it.
By their numbers in this assay, from the lowest: compounds 3, 1, 4 and 2 (each within the scatter of the next).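

In this assay, iodo on this aromatic carbon leaves the number where the other three substituents put it: a 1.0-fold higher number from compound 3 to compound 4 (0.01 log units; within the scatter), a 1.1-fold lower number from compound 2 to compound 4 (0.05 log units; within the scatter), and a 1.0-fold higher number from compound 1 to compound 4 (0.01 log units; within the scatter). The insensitivity seen among methyl, chloro and bromo therefore extends to a fourth substituent, and all three steps into iodo, whether from a halogen or from methyl, stay within the scatter. The data offer no explanation for this flat result.

Going by these compounds, what remains open is whether a different kind of group on this carbon, such as an amine or a carboxylic acid, would shift the number beyond the scatter. Since all four compounds share the same core and chain, they also leave open what a longer chain would do.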